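Adding a Methoxy Group to the Core of Compound 2

The compounds below may be only part of what the source reports. "The series", "measured", "known", "first", "only" and "open" are said of these compounds alone.

Of the compounds shown here, three sharing a core have been measured in a functional assay on NSCLC cells (Homo sapiens) for cytotoxicity, with a stated time of 48 h; a lower number here means a stronger inhibitor of growth, a higher number a weaker inhibitor of growth. Compound 1 `O=C1/C(=C/c2c(Cl)[nH]c3ccccc23)c2ccccc2N1Cc1ccccc1` gives 6610 nM in this assay. Compound 2 `COc1c(/C=C2/C(=O)Nc3ccccc32)c2ccccc2n1-c1ccccc1` gives 2140 nM. Compound 3 `COc1cc2c(c(OC)c1OC)/C(=C\c1c(Cl)[nH]c3ccccc13)C(=O)N2` gives 1860 nM.

Compound 2 holds the second highest of the three numbers. Its nearest neighbour is compound 3, whose number sits within the usual scatter of that of compound 2, so the two cannot be told apart. Its furthest neighbour is compound 1, whose number lies higher by a margin beyond the scatter, so compound 1 is the weaker inhibitor of growth of that pair.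

Compound 4 `COc1ccc2c(c1)/C(=C\c1c(OC)n(-c3ccccc3)c3ccccc13)C(=O)N2` has not yet been measured. It differs from compound 2 in one place: methoxy in place of hydrogen on an aromatic carbon. Within the data shown here, no pair of measured compounds differs by this change alone, so the size of the step cannot be read from the data. Compound 3, whose core carries methoxy groups, gives 1860 nM, close to the number of compound 2, which suggests that such substitution leaves the number largely unchanged. Compound 4 is therefore expected to give 1800 nM, with a range from 600 nM to 5500 nM. The expected step of a 1.2-fold lower number from compound 2 to compound 4 (0.08 log units; within the scatter) is small, with at most a slight lean toward a lower number and nothing beyond the scatter.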

Compound 4, concentration for 50% growth inhibition: 2510 nM
For compound 4 the middle estimate is 1.4-fold (0.14 log units) below the measured one; low and high end bracket the measured number.
By their numbers in this assay, from the lowest: compounds 3, 2 and 4 (each within the scatter of the next); then compound 1.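

Placing methoxy in place of hydrogen on an aromatic carbon of the six-membered aromatic ring of carbon only, meta to a fused ring and para to a fused ring, gives in this assay a 1.2-fold higher number from compound 2 to compound 4 (0.07 log units; within the scatter). Among these compounds, this is the first pair of measured compounds that differs by this change alone, so the size of the step can now be read directly rather than inferred, and it shows that this position on the core carries a methoxy group with no shift in the number beyond the scatter. No measured evidence is available that bears on this result.

The compounds shown cover only hydrogen and methoxy at this position, so it remains open whether an amine, a carboxylic acid or a longer chain such as butoxy would also stay within the scatter of compound 2 or would move the number beyond it. Going by these compounds, the step also rests on a single pair, and whether the same change on the core of compound 1 would give a step of similar size remains open.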